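A few compounds are considered here, and "the series" means these few. Any claim that something is new, unique, unknown or untested is made for them only; others in the source may bear on it.

In an ADME assay on Vero cells (Chlorocebus sabaeus) for cytotoxicity (a higher number here means a weaker inhibitor, a lower number a stronger inhibitor), compound 1 (`COc1ccc(Cn2cc(CNC(=O)c3ccc([N+](=O)[O-])o3)nn2)cc1O`) gives 174000 nM and compound 2 (`O=C(NCc1cn(Cc2ccc([N+](=O)[O-])cc2)nn1)c1ccc([N+](=O)[O-])o1`) gives 291000 nM, with the two values within the scatter of each other. Compound 3 (`COc1cc(Cn2cc(CNC(=O)c3ccc([N+](=O)[O-])o3)nn2)ccc1F`) is not yet measured, and its change from compound 1 is 4-fluoro-3-methoxyphenyl in place of 3-hydroxy-4-methoxyphenyl on a saturated chain carbon bound to an aromatic nitrogen at the same place, a saturated chain carbon bound to an aromatic nitrogen. Among the measured compounds shown here, the only measured step at this place is a 1.7-fold higher number from compound 1 to compound 2 (0.22 log units; within the scatter) and it is a single guide, so no shift beyond the scatter is expected in this assay for this swap. The expected size is a 1.1-fold higher number from compound 1 to compound 3 (0.06 log units; within the scatter) as estimated here. Compound 3 is estimated at 200000 nM (range 90000 nM to 420000 nM).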

Compound 3, half-maximal inhibitory concentration: 225000 nM
Compound 3: the middle estimate sits 1.1-fold (0.05 log units) below what was measured; measured number inside the range.
By their numbers in this assay, from the lowest: compounds 1, 3 and 2 (each within the scatter of the next).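

In this assay, 4-fluoro-3-methoxyphenyl on this saturated chain carbon reads the same as 3-hydroxy-4-methoxyphenyl within the scatter (a 1.3-fold higher number from compound 1 to compound 3 (0.11 log units; within the scatter)) and the same as 4-nitrophenyl within the scatter (a 1.3-fold lower number from compound 2 to compound 3 (0.11 log units; within the scatter)). The swap from compound 1 also takes the count of hydrogen-bond donors in this group from 1 to 0, and no shift beyond the scatter comes with it. Nothing available explains this result. All three compounds carry a substituted phenyl group here. On these data alone, whether an amine or a carboxylic acid at this place would shift the number beyond the scatter remains open.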